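Lengthening the Alkyl Chain on the Aminoquinazoline Nitrogen

A few compounds are considered here, and "the series" means these few. Any claim that something is new, unique, unknown or untested is made for them only; others in the source may bear on it.

Among the measured compounds shown here, compound 2 `CCCNc1nc(NCc2ccc(C(=O)Nc3ccc(F)cc3)cc2)c2ccccc2n1` gives 1600 nM in a functional assay on SW480 cells (Homo sapiens) for inhibition, read by luminescence and resazurin assay, with a stated time of 3 days; a higher number here means a weaker inhibitor, a lower number a stronger inhibitor; it is one of only two numbers measured, and the other, compound 1 `O=C(Nc1ccc(F)cc1)c1ccc(CNc2nc(NC3CC3)nc3ccccc23)cc1`, gives 2600 nM, so the two lie within the scatter of each other. For the measured compounds named here, the single measured step, a 1.6-fold lower number from compound 1 to compound 2 (0.21 log units; within the scatter), is small. Compound 3 `CCCCNc1nc(NCc2ccc(C(=O)Nc3ccc(F)cc3)cc2)c2ccccc2n1` differs from compound 2 by methyl in place of hydrogen on a saturated chain carbon, three bonds along the chain from a nitrogen on an aromatic ring. Going by the values given here, only the step from compound 1 to compound 2 touches this nitrogen substituent, and nothing measured addresses lengthening the chain itself. Compound 3 is therefore estimated at 1400 nM, within 600 nM to 3500 nM. The expected step, a 1.1-fold lower number from compound 2 to compound 3 (0.06 log units; within the scatter), stays within the scatter.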

Compound 3, half-maximal inhibitory concentration: 1000 nM
For compound 3 the middle estimate is 1.4-fold (0.15 log units) above the measured one, and the stated range covers the measured number.
By their numbers in this assay, from the lowest: compounds 3, 2 and 1 (each within the scatter of the next, the first and the last beyond it).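

Extending propyl to butyl gives a 1.6-fold lower number from compound 2 to compound 3 (0.20 log units; within the scatter) in this assay and so these two chains cannot be told apart at this nitrogen. Butyl in place of cyclopropyl gives a 2.6-fold lower number from compound 1 to compound 3 (0.41 log units; beyond the scatter) and this is the first step at this position to clear the scatter, although only modestly. Nothing available explains either step. On these data alone, whether a pentyl chain, a branched isopropyl group or a chain ending in an amine would shift the number at this nitrogen remains open.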